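Removing the Nitro Group from a Weakly Active Core

The source may hold more compounds than are shown below. What is called first, only, known or untested is meant among the compounds shown, and "the series" means these compounds.

Measured so far:
compound 1 `COc1ccc(C2(O)SC=C(C)n3c2noc3=O)cc1`: > 100000 nM
compound 2 `CC1=CSC(O)(c2cccc([N+](=O)[O-])c2)c2noc(=O)n21`: 159000 nM
compound 3 `CCCCCOC1(c2ccc(Cl)cc2)SC=C(C)n2c1noc2=O`: > 100000 nM

Of the compounds shown here, three built on one shared core have been tested in a functional assay on A2780 cells (Homo sapiens) for antiproliferative activity, read by MTT assay, with a stated time of 3 days; on this read-out lower numbers stand for stronger inhibition and higher numbers for weaker inhibition. For compound 1 the value > 100000 nM is a limit of the assay rather than a number. For compound 3 the value > 100000 nM is likewise a limit. For the measured compounds named here, compound 2, at 159000 nM, is therefore the only compound of the three that returns an actual number in this assay. The only reference point for it is the limit of > 100000 nM in this assay, at which 2 of the 3 values shown sit, and compound 2 does not stand far from that point.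

Compound 4 `CC1=CSC(O)(c2ccccc2)c2noc(=O)n21` differs from compound 2 by hydrogen in place of nitro on an aromatic carbon. Going by the values given here, no pair of measured compounds differs in a single place, so the size of this change in this assay cannot be read from the data. Given that compound 2 and both limits lie in the same weak region, no step beyond the scatter is expected in either direction.

Compound 4 is accordingly expected to give about 150000 nM, within 50000 nM to 500000 nM, with a real chance that the assay again reports only a limit. That estimate corresponds to a step of a 1.1-fold lower number from compound 2 to compound 4 (0.03 log units; within the scatter), expected to fall within the usual scatter.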

Compound 4, half-maximal inhibitory concentration: > 100000 nM
Compound 4 gave a limit, no number; the forecaster's own chance of this, stated with the estimate: 60%; the middle value does not contradict the limit.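

In this assay compound 4 gives > 100000 nM as a limit and not a number, so the steps to it from compound 2 and from compound 1 cannot be read: the limit of > 100000 nM in this assay, at which 3 of the 4 values shown sit.

The compounds shown leave open how far hydrogen in place of nitro or methoxy on the aromatic carbon moves the value in this assay.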